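Shortening the long chain on a benzyl-bearing purine diamine

The compounds below may be only part of what the source reports. "The series", "measured", "known", "first", "only" and "open" are said of these compounds alone.

Measured compounds:
Compound 1, `CCCCCCCCCCCCCCCCCC/N=c1\nc(N)c2nc[nH]c2c(N)n1`: 3530 nM
Compound 2, `CCCCCCCCCCCCCCCCCC/N=c1\nc(N)c2ncn(Cc3ccccc3)c2c(N)n1`: 8300 nM

In a functional assay on MCF7 cells (Homo sapiens) for antiproliferative activity, read by WST assay, with a stated time of 72 h (a higher number here means a weaker inhibitor, a lower number a stronger inhibitor), compound 1 gives 3530 nM and compound 2 gives 8300 nM. Among the measured compounds shown here, compound 2 therefore carries the highest of the two numbers measured so far, and its nearest neighbour is compound 1, reached by the single measured step of a 2.4-fold higher number from compound 1 to compound 2 (0.37 log units; beyond the scatter).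

Compound 3, `CCCCCCCC/N=c1\nc(N)c2ncn(Cc3ccccc3)c2c(N)n1`, differs from compound 2 by hydrogen in place of decyl on a saturated chain carbon, eight bonds along the chain from a double-bonded nitrogen. For the measured compounds named here, no measured step bears on this kind of change: the one step on record concerns the aromatic nitrogen, not the chain, so it gives no guide to the size or the direction of the change in this assay. The expectation for compound 3 is accordingly wide and leans toward a weaker result, with the step from compound 2 to compound 3 estimated as a 1.8-fold higher number from compound 2 to compound 3 (0.26 log units; within the scatter). In this assay compound 3 is expected to give about 15000 nM, within a range from 4000 nM to 60000 nM.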

Compound 3, half-maximal inhibitory concentration: 4550 nM
Compound 3: the middle estimate sits 3.3-fold (0.52 log units) above what was measured; the measured number falls inside the stated range.
By their numbers in this assay, from the lowest: compounds 1, 3 and 2 (each within the scatter of the next, the first and the last beyond it).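

In this assay, among the compounds shown here, hydrogen in place of decyl on a saturated chain carbon, eight bonds along the chain from a double-bonded nitrogen, gives a 1.8-fold lower number from compound 2 to compound 3 (0.26 log units; within the scatter) and so tests the chain itself for the first time. Within this pair, the loss of these 10 carbon atoms leaves the two numbers within the scatter of each other, so the decyl portion is not shown to matter for the read-out. Nothing available offers an explanation for this result.

A single pair cannot show whether a butyl chain, or a chain ending in an amine or a carboxylic acid, would leave the number similarly unchanged. It also leaves open whether the same change would read alike with hydrogen rather than benzyl on the aromatic nitrogen.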